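The source may report more compounds than this note shows. Statements on the series, on what has been measured and on what is new or still open speak of the compounds shown alone.

Compound 1 `CCc1ccc(Nc2nc3nonc3nc2O)cc1` is one of three compounds sharing a common core, all measured in an assay on mitochondria from L6 cells (Rattus norvegicus) for activation, with a stated time of 90 min (a lower number here means that less compound is needed, a higher number that more compound is needed for the effect), where compound 1 gives 10700 nM. This is the highest of the three numbers. Compound 3 `CCc1ccc(Nc2nc3nonc3nc2O)c(F)c1` gives 6700 nM, and the change a 1.6-fold lower number from compound 1 to compound 3 (0.20 log units; within the scatter) involves a fluoro in place of hydrogen on an aromatic carbon. Compound 2 `CC(C)(C)c1cccc(Nc2nc3nonc3nc2O)c1` gives 2200 nM, which is beyond the scatter from compound 1, though no single-step comparison connects these two.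

Compound 4 `Oc1nc2nonc2nc1Nc1ccc(F)cc1` has not yet been measured. It differs from compound 1 as follows: fluoro in place of ethyl on an aromatic carbon. Within the data shown here, the only measured step involving a fluoro, from compound 1 to compound 3, was within the scatter, but it added a fluoro rather than exchanging it for an ethyl, so it bears only loosely on this change. Among the measured compounds shown here, no measured step removes an ethyl. The steps therefore give no firm direction, and the expected change a 1.4-fold higher number from compound 1 to compound 4 (0.15 log units; within the scatter) is one of little movement, with a slight lean towards a higher number. Compound 4 is estimated at 15000 nM, within a range from 5000 nM to 45000 nM.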

Compound 4, half-maximal effective concentration: 38600 nM
Estimate against measurement, compound 4: 2.6-fold (0.41 log units) below; the measured number falls inside the stated range.
By their numbers in this assay, from the lowest: compound 2; then compounds 3 and 1 (each within the scatter of the next); then compound 4.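

Among these compounds, exchanging the ethyl for a fluoro on this aromatic carbon, para to a large group, is the first single change from compound 1 that moves the number beyond the scatter: in this assay it gives a 3.6-fold higher number from compound 1 to compound 4 (0.56 log units; beyond the scatter). Among the compounds shown here, the only earlier step, a 1.6-fold lower number from compound 1 to compound 3 (0.20 log units; within the scatter), stayed within the scatter, so adding a fluoro alongside the ethyl showed little, while losing the ethyl at this position does show up in the read-out. No measured information accounts for this shift.

The compounds shown cannot separate the effect of removing the ethyl from that of bringing in the fluoro. A plain hydrogen, a methoxy or a longer chain such as propyl at this position would help tell these apart and show how far the trend runs.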